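A 2-Methoxyphenyl Swap on an Amide-Type Nitrogen

A few compounds are considered here, and "the series" means these few. Any claim that something is new, unique, unknown or untested is made for them only; others in the source may bear on it.

Measured in a functional assay on MCF7 cells (Homo sapiens) for antiproliferative activity, read by MTT assay; a higher number here means a weaker inhibitor, a lower number a stronger inhibitor:
Compound 1 `COc1cc2c(Oc3ccc(NC(=O)Nc4ccc(C(F)(F)F)cc4Cl)cc3)ccnc2cc1OCCCCCCC(=O)NO`: 500 nM
Compound 2 `COc1cc2c(Oc3ccc(NC(=O)Nc4ccc(C)cc4C)cc3)ccnc2cc1OCCCCCCC(=O)NO`: 3430 nM

Of these two compounds, compound 2 has the higher number and is the weaker inhibitor, at 3430 nM. The next compound to be tested in this assay is compound 3 `COc1ccccc1NC(=O)Nc1ccc(Oc2ccnc3cc(OCCCCCCC(=O)NO)c(OC)cc23)cc1`, which carries 2-methoxyphenyl in place of 2,4-dimethylphenyl on an amide-type nitrogen.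

Among the measured compounds shown here, only one measured step bears on this change. It occurs on an amide-type nitrogen as well, where 2,4-dimethylphenyl takes the place of 2-chloro-4-(trifluoromethyl)phenyl, and it is modest but beyond the scatter: a 6.9-fold higher number from compound 1 to compound 2 (0.84 log units; beyond the scatter). That step shows that the number can move with the group at this place. For the measured compounds named here, it involves a different incoming group, however, and no measured compound carries 2-methoxyphenyl, so it gives no firm direction for the new change. A smaller step than a 6.9-fold higher number from compound 1 to compound 2 (0.84 log units; beyond the scatter) is therefore expected, probably none beyond the scatter, with a slight lean towards a lower number. The expected step is a 1.4-fold lower number from compound 2 to compound 3 (0.14 log units; within the scatter). For compound 3 the estimated value is 2500 nM, with an expected range of 800 nM to 7000 nM.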

Compound 3, half-maximal inhibitory concentration: 6280 nM
The estimate for compound 3 lay 2.5-fold (0.40 log units) below the measured number; measured number inside the range.
By their numbers in this assay, from the lowest: compound 1; then compounds 2 and 3 (each within the scatter of the next).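

In this assay the exchange of 2,4-dimethylphenyl for 2-methoxyphenyl on the amide-type nitrogen gives a 1.8-fold higher number from compound 2 to compound 3 (0.26 log units; within the scatter) and so stays inside the scatter: on this read-out, a group with 1 hydrogen-bond acceptor and a group with 0 cannot be told apart at this place. The 2-chloro-4-(trifluoromethyl)phenyl group now stands apart from two different replacements rather than one, with a 13-fold higher number from compound 1 to compound 3 (1.10 log units; beyond the scatter) as a large step alongside the modest 6.9-fold higher number from compound 1 to compound 2 (0.84 log units; beyond the scatter) on the same nitrogen, so that among the three compounds shown only compound 1 is separated from the others beyond the scatter. No measured evidence in hand accounts for these numbers.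

The compounds shown leave open whether the chlorine or the trifluoromethyl group of compound 1 goes with its lower number, as the two occur only together, in that one compound. Nor do they show how a phenyl ring carrying a lone chlorine, a lone trifluoromethyl or a nitrile would read at this place, or an unsubstituted phenyl ring.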